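The source may report more compounds than this note shows. Statements on the series, on what has been measured and on what is new or still open speak of the compounds shown alone.

Measured so far:
- compound 1, `COc1ccc([C@@H]2C/C(=N/OCc3cn(-c4cccc(CO)c4)nn3)c3cc(CC=C(C)C)c(OC)cc3O2)cc1`: 42%
- compound 2, `COc1ccc([C@@H]2C/C(=N/OCc3cn(-c4ccc(C#N)cc4)nn3)c3cc(CC=C(C)C)c(OC)cc3O2)cc1`: 40%
- compound 3, `COc1ccc([C@@H]2C/C(=N/OCc3cn(-c4ccc(NC(=O)c5ccccc5)cc4)nn3)c3cc(CC=C(C)C)c(OC)cc3O2)cc1`: 4%

In a functional assay on MCF7 cells (Homo sapiens) for inhibition, read by sulforhodamine B assay, with a stated time of 48 h, tested at 50 uM (a lower number here means less inhibition of growth, a higher number more inhibition of growth at the concentration tested), compound 3 stands lowest of the three numbers. Its nearest neighbour is compound 2, and the step of a number 36 percentage points lower from compound 2 to compound 3 (beyond the scatter) lies beyond the scatter, as does the gap to compound 1. The other measured step, a number 2 percentage points lower from compound 1 to compound 2 (within the scatter), lies within the scatter. Compound 4, `COc1ccc([C@@H]2C/C(=N/OCc3cn(-c4ccc(NC(C)=O)cc4)nn3)c3cc(CC=C(C)C)c(OC)cc3O2)cc1`, has not yet been measured in this assay. It differs from compound 3 in one place: methyl in place of phenyl on a carbonyl carbon. Among the measured compounds shown here, the only measured step that touches the same part of the molecule is the one from compound 2 to compound 3, in which benzamido entered in place of cyano and the number fell by a large amount. For the measured compounds named here, no measured pair shows methyl in place of phenyl on a carbonyl carbon, so the direction and size of the step from compound 3 to compound 4 cannot be read from a matched step. Since the benzamido group brought the large fall, compound 4 is expected to lie somewhat above compound 3, and the expected step of a number 14 percentage points higher from compound 3 to compound 4 (beyond the scatter) is estimated as a moderate rise. For compound 4 the estimate in this assay is 18%, with a range from 2% to 40%.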

Compound 4, percent growth inhibition at one concentration: 0%
The estimate for compound 4 lay 18 percentage points above the measured number, and the stated range ends above it.
By their numbers in this assay, from the lowest: compounds 4 and 3 (each within the scatter of the next); then compounds 2 and 1 (each within the scatter of the next).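

In this assay the step from benzamido to acetamido brought no recovery (a number 4 percentage points lower from compound 3 to compound 4 (within the scatter)), so on this carbonyl carbon, methyl in place of phenyl made no difference beyond the scatter. The large fall seen with benzamido therefore did not depend on the phenyl group, since the smaller acetamido group shows a fall of the same kind, both in place of cyano on the aromatic carbon (a number 40 percentage points lower from compound 2 to compound 4 (beyond the scatter)) and in the wider change from the 3-(hydroxymethyl)phenyl group on the aromatic nitrogen (a number 42 percentage points lower from compound 1 to compound 4 (beyond the scatter)). Nothing at hand accounts for why the two amides stand so far below the nitrile.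

The compounds shown leave open whether a free amine or a carboxylic acid in place of the whole amide on the aromatic carbon would stand with the nitrile or with the two amides. They also leave open whether a longer alkyl chain on the carbonyl carbon, or an amine in place of its methyl, would shift the number at all from where compound 3 and compound 4 stand.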